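The source may report more compounds than this note shows. Statements on the series, on what has been measured and on what is new or still open speak of the compounds shown alone.

Compound 1 `COc1cc(-c2nn(-c3cccc(NC(=O)Nc4cc(C(F)(F)F)cc(C(F)(F)F)c4)c3)cc2-c2ccncc2)ccc1Cl` is the starting point of this small series. In a functional assay on HOP-92 cells (Homo sapiens) for inhibition, read by sulforhodamine B assay, with a stated time of 48 h (on this read-out lower numbers stand for stronger inhibition and higher numbers for weaker inhibition), compound 1 gives 140 nM. Compound 2 `O=C(Nc1cccc(-n2cc(-c3ccncc3)c(-c3ccc(Cl)c(O)c3)n2)c1)Nc1cc(C(F)(F)F)cc(C(F)(F)F)c1` carries one change relative to compound 1, namely (hydrogen in place of methyl on an oxygen on an aromatic ring), and in this assay compound 2 gives 340 nM. That single change produced a 2.4-fold higher number from compound 1 to compound 2 (0.39 log units; beyond the scatter), so the number moved upward, meaning weaker inhibition.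

Compound 3 `COc1cc(-c2nn(-c3cccc(NC(=O)Nc4ccc(Cl)c(C(F)(F)F)c4)c3)cc2-c2ccncc2)ccc1Cl` belongs to the same family but has a different core; the difference between the core of compound 1 and the core of compound 3 is not broken down here. In this assay compound 3 gives 500 nM.

Compound 4 `O=C(Nc1cccc(-n2cc(-c3ccncc3)c(-c3ccc(Cl)c(O)c3)n2)c1)Nc1ccc(Cl)c(C(F)(F)F)c1` has not yet been tested. It stands to compound 3 as compound 2 stands to compound 1: the change is hydrogen in place of methyl on an oxygen on an aromatic ring, and the place of the change reads word for word the same in both pairs, so it is the same change. Because the earlier step was a 2.4-fold higher number from compound 1 to compound 2 (0.39 log units; beyond the scatter), a step of similar size and direction is expected, that is a 2.4-fold higher number from compound 3 to compound 4 (0.38 log units; beyond the scatter). On that basis compound 4 is estimated to give 1200 nM, with a plausible range from 500 nM to 2800 nM.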

Compound 4, half-maximal inhibitory concentration: 380 nM
Estimate against measurement, compound 4: 3.2-fold (0.50 log units) above, outside the stated range (below it).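

The methoxy to hydroxy change does not carry over as a fixed step between the two cores in this assay: the same change on two cores in this assay, a 2.4-fold higher number (0.39 log units; beyond the scatter) from compound 1 to compound 2 and a 1.3-fold lower number (0.12 log units; within the scatter) from compound 3 to compound 4, 3.2-fold (0.50 log units) apart, beyond the scatter of two such steps. On the core of compound 3 the change gives a 1.3-fold lower number from compound 3 to compound 4 (0.12 log units; within the scatter), so this pair cannot be told apart in this test, and the loss of inhibition seen on the core of compound 1 does not reappear. This shows that, in these two pairs, the effect of the change depends on the core it sits on, but two pairs do not show which feature of the core matters, why the steps differ, or what the change would do on any further core.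

From the compounds shown here alone, it remains open whether an amine or an ethoxy group in place of the methoxy would also behave differently on the two cores. Going by these compounds, it is also open whether the same gap between the two steps would appear in other cell lines.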